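A few compounds are considered here, and "the series" means these few. Any claim that something is new, unique, unknown or untested is made for them only; others in the source may bear on it.

Measured so far in a functional assay on Huh7.5.1 cells (Homo sapiens) for cytotoxicity, read by MTT assay, with a stated time of 72 h; a higher number here means that more compound is tolerated, a lower number that less compound is tolerated:
Compound 1 `C=c1[nH]c(=O)/c(=C/c2ccc(C)cc2)[nH]c1=O` gives only the assay limit > 20000 nM.
Compound 2 `C=c1[nH]c(=O)/c(=C/c2ccsc2)[nH]c1=O` gives only the assay limit > 20000 nM.
Compound 3 `C=c1[nH]c(=O)/c(=C/c2ccoc2)[nH]c1=O` gives only the assay limit > 20000 nM.

For the measured compounds named here, compound 1 therefore stands where every value so far sits, at the limit of > 20000 nM in this assay, at which 3 of the 3 values shown sit, and nothing separates it from the rest. Going by the values given here, the one single-point change measured, a step that the two limits leave unreadable from compound 2 to compound 3, is unreadable because both ends are limits. Compound 4 `C=c1[nH]c(=O)/c(=C/c2ccc(OC)cc2)[nH]c1=O` differs from compound 1 by methoxy in place of methyl on an aromatic carbon. Among the compounds with values here, no measured step informs this change, and the three limits give no direction. Compound 4 is expected to stay at the limit as well, so the step that the limit leaves unreadable from compound 1 to compound 4 is expected to be none beyond the scatter. The estimate for compound 4 in this assay is 25000 nM, within 12000 nM to 60000 nM.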

Compound 4, half-maximal cytotoxic concentration: > 20000 nM
Compound 4: no number, only a limit; the forecaster's own chance of this, stated with the estimate: 85%; the middle value does not contradict the limit.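

Compound 1 and compound 4 both give only a limit, so the step between them, methoxy in place of methyl, cannot be read: the limit of > 20000 nM in this assay, at which 4 of the 4 values shown sit.

The compounds shown leave open what change in the shared core's substituents, if any, would yield an actual number in this assay.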